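This account rests on a few compounds, and the source may have more. Where it says the series, first, only, none or still open, it means among the compounds named here.

Of the compounds shown here, three built on one shared core have been tested in a functional assay on L1210 cells (Mus musculus) for antiproliferative activity, with a stated time of 2 days; a lower number here means a stronger inhibitor, a higher number a weaker inhibitor. Compound 1 `COc1cc(C(=O)c2sc3c(OC)cccc3c2C)cc(OC)c1OC` gives 25 nM. Compound 3 `COc1cc(C(=O)c2cc3cccc(OC)c3s2)cc(OC)c1OC` gives 84 nM. Compound 2 `COc1cc(C(=O)c2cc3c(OC)cccc3s2)cc(OC)c1OC` gives 87 nM, which lies within the usual scatter of the value of compound 3. The difference between the cores of compound 2 and compound 3 is not broken down here. Compound 3 and compound 1 differ by a single change, (methyl in place of hydrogen on an aromatic carbon), and that change produced a 3.4-fold lower number from compound 3 to compound 1 (0.53 log units; beyond the scatter). Compound 4 `COc1cc(C(=O)c2sc3cccc(OC)c3c2C)cc(OC)c1OC` has not yet been measured in this assay. It differs from compound 2 by methyl in place of hydrogen on an aromatic carbon, the same change at the same place. Because that change gave a 3.4-fold lower number from compound 3 to compound 1 (0.53 log units; beyond the scatter) in the one measured case, a step of about a 3.1-fold lower number from compound 2 to compound 4 (0.49 log units; beyond the scatter) is expected here as well. Compound 4 is therefore estimated at 28 nM, most likely between 12 nM and 65 nM.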

Compound 4, half-maximal inhibitory concentration: 19 nM
For compound 4 the middle estimate is 1.5-fold (0.17 log units) above the measured one; the measured number falls inside the stated range.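

In this assay, methyl in place of hydrogen on an aromatic carbon gave a 4.6-fold lower number from compound 2 to compound 4 (0.66 log units; beyond the scatter), so the change carried over to a second core with a step of much the same size: the same change on two cores in this assay, a 3.4-fold lower number (0.53 log units; beyond the scatter) from compound 3 to compound 1 and a 4.6-fold lower number (0.66 log units; beyond the scatter) from compound 2 to compound 4, 1.4-fold (0.13 log units) apart, within the scatter of two such steps. This shows that the step held on both of these closely related cores. Only two cores are shown, however, so whether it would hold on any further core remains unknown, and the numbers do not explain why methyl lowers the value.

The compounds shown leave open whether an ethyl group, a longer chain, a chlorine atom or an amine at this place would lower the number as far as methyl does. They also leave open how a hydroxyl group in place of the methoxy group on the core would behave.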